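The source may report more compounds than this note shows. Statements on the series, on what has been measured and on what is new or still open speak of the compounds shown alone.

Measured in a toxicity assay on HepG2 cells (Homo sapiens) for inhibition, read by resazurin assay, with a stated time of 24 h (a lower number here means that less compound is tolerated, a higher number that more compound is tolerated), as follows:

compound 1 `COc1cccc(CNC(=O)c2ncc([N+](=O)[O-])n2C)c1` gives > 100000 nM
compound 2 `Cn1c([N+](=O)[O-])cnc1C(=O)NCc1ccccn1` gives > 100000 nM
compound 3 `CN(C)C(=O)c1ncc([N+](=O)[O-])n1C` gives > 100000 nM

Each of these readings is a limit of the assay and not a number. Compound 3 stands at > 100000 nM as a limit, with no number of its own. Among the measured compounds shown here, the whole set so far is described by the limit of > 100000 nM in this assay, at which 3 of the 3 values shown sit, and offers no step between measured compounds to go by.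

Compound 4 `Cn1c([N+](=O)[O-])cnc1C(=O)N1CCCC1` carries pyrrolidin-1-yl in place of dimethylamino on a carbonyl carbon.

In this assay no step beyond the scatter is expected for this change. The expectation rests on compound 3 at > 100000 nM as a limit, and the reading for the new compound may well be a limit too. The expected step is a number no higher from compound 3 to compound 4 (the limit leaves the size open) in size. For compound 4 the estimate is 100000 nM as a central value, with an expected range from 50000 nM to 200000 nM for the half-maximal cytotoxic concentration.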

Compound 4, half-maximal cytotoxic concentration: > 100000 nM
Compound 4 was reported as a limit; the forecaster's own chance of this, stated with the estimate: 85%; the middle value sits exactly at the limit.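

In this assay no step can be read between compound 3 and compound 4, as both readings are limits. The compounds shown leave open the half-maximal cytotoxic concentration of each, and whether the group on the carbonyl carbon changes it at all: the limit of > 100000 nM in this assay, at which 4 of the 4 values shown sit.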